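Phenyl in place of 2-chlorophenyl in the thiazepinone acrylamide series

The source may hold more compounds than are shown below. What is called first, only, known or untested is meant among the compounds shown, and "the series" means these compounds.

Going by the values given here, compound 2 `C=CC(=O)N1C(=O)CC(c2ccccc2Cl)Sc2ccccc21` gives 80300 nM in a functional assay on MOLT-4 cells (Homo sapiens) for cytotoxicity, read by CCK-8 assay, with a stated time of 24 h (on this read-out lower numbers stand for stronger inhibition and higher numbers for weaker inhibition), the lowest of the three numbers so far, though the gap to compound 1 `C=CC(=O)N1C(=O)CC(c2ccc(OC)cc2)Sc2ccccc21` lies within the scatter: in this assay compound 1 gives 83200 nM, and the step of a 1.0-fold lower number from compound 1 to compound 2 (0.02 log units; within the scatter) is uninformative. Compound 3 `C=CC(=O)N1C(=O)CCSc2ccccc21`, carrying hydrogen on the saturated ring carbon instead of an aryl group, gives 565000 nM in this assay, so the steps of a 6.8-fold higher number from compound 1 to compound 3 (0.83 log units; beyond the scatter) and a 7.0-fold higher number from compound 2 to compound 3 (0.85 log units; beyond the scatter) show that removing the whole aryl group costs a modest but real amount.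

Compound 4 `C=CC(=O)N1C(=O)CC(c2ccccc2)Sc2ccccc21` differs from compound 2 as follows: hydrogen in place of chloro on an aromatic carbon. The aryl group stays; only the chloro leaves. The step of a 1.0-fold lower number from compound 1 to compound 2 (0.02 log units; within the scatter) is the one that bears most directly, since it swaps one substitution pattern on the aryl group for another with no change beyond the scatter; the steps to compound 3 concern loss of the aryl group as a whole and set the far boundary. The expected step of a 1.2-fold higher number from compound 2 to compound 4 (0.10 log units; within the scatter) in this assay is therefore none beyond the scatter, with a slight lean toward a higher number in case the chloro itself carried some of the aryl group's contribution. Compound 4 is estimated at 100000 nM, within a range of 50000 nM to 250000 nM.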

Compound 4, half-maximal inhibitory concentration: 85900 nM
The estimate for compound 4 lay 1.2-fold (0.07 log units) above the measured number, within the range that was stated.
By their numbers in this assay, from the lowest: compounds 2, 1 and 4 (each within the scatter of the next); then compound 3.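

In this assay the unsubstituted phenyl group holds its place with the substituted ones: a 1.1-fold higher number from compound 2 to compound 4 (0.03 log units; within the scatter) and a 1.0-fold higher number from compound 1 to compound 4 (0.01 log units; within the scatter) both leave the number unchanged within the scatter, so neither the chloro nor the methoxy is needed at the level this read-out can resolve. The step of a 6.6-fold lower number from compound 3 to compound 4 (0.82 log units; beyond the scatter) then shows that the plain phenyl on the saturated ring carbon accounts for the full difference from the hydrogen compound, which the earlier steps could attribute only to substituted aryl groups. Nothing available gives a reason for this flat response to aryl substitution.

Going by these compounds, compounds 1, 2 and 4 cover only phenyl, 2-chlorophenyl and 4-methoxyphenyl, so it remains open whether an amine or a carboxylic acid on the aryl group, or a longer chain in place of the phenyl, would shift the number beyond the scatter. All four compounds carry the acrylamide, so they also leave open what a saturated propanoyl group in its place would do in this assay on the shared core.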